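The source may hold more compounds than are shown below. What is called first, only, known or untested is meant among the compounds shown, and "the series" means these compounds.

In an ADME assay on Vero cells (Chlorocebus sabaeus) for cytotoxicity, read by MTT assay (on this read-out higher numbers stand for lower toxicity in this test and lower numbers for higher toxicity in this test), compound 1 `C[Si](C)(C)C#Cc1c[nH]c(=O)[nH]c1=O` gives 270000 nM. Compound 2 `CCCCC#Cc1cn([C@@H]2O[C@H](CO)[C@@H](O)[C@H]2O)c(=O)[nH]c1=O` stands lowest of the two numbers in this assay, where compound 2 gives 103000 nM; compound 1 sits above it by a margin beyond the scatter. Compound 3 `O=c1[nH]c(=O)n([C@@H]2O[C@H](CO)[C@@H](O)[C@H]2O)cc1C#Cc1ccccc1` differs from compound 2 in one place: phenyl in place of butyl on a triple-bonded carbon. For the measured compounds named here, no measured pair shows this change, so the step from compound 2 is expected to be small, if anything a modest move toward lower numbers in this assay, and it may stay within the scatter. The expected step is a 1.3-fold lower number from compound 2 to compound 3 (0.11 log units; within the scatter). Compound 3 is estimated at 80000 nM, within 30000 nM to 250000 nM.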

Compound 3, half-maximal cytotoxic concentration: 78400 nM
Compound 3: the middle estimate sits 1.0-fold (0.01 log units) above what was measured, within the range that was stated.
By their numbers in this assay, from the lowest: compounds 3 and 2 (each within the scatter of the next); then compound 1.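

In this assay, phenyl in place of butyl on a triple-bonded carbon gives a 1.3-fold lower number from compound 2 to compound 3 (0.12 log units; within the scatter) and so leaves the number within the scatter. For the compounds shown here, this is the first direct reading at this place: in this pair, a six-membered aromatic ring and an open chain are not told apart by this test. Nothing measured here offers an explanation for this result. The compounds shown leave open whether an amine, a carboxylic acid or a chain longer than butyl on this triple-bonded carbon would move the number beyond the scatter.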